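Notes on compound 4, the ethyl analogue of compound 1

The compounds below may be only part of what the source reports. "The series", "measured", "known", "first", "only" and "open" are said of these compounds alone.

Measured compounds:
compound 1 `Cc1c(C(=O)Nc2ccc(Oc3ncnc4[nH]cc(-c5ccccc5)c34)c(F)c2)c(=O)c2ccccc2n1C` gives > 10000 nM, a limit of the assay.
compound 2 `Cc1c(C(=O)Nc2ccc(Oc3ncnc4[nH]cc(-c5ccccc5)c34)c(F)c2)c(=O)c2ccc(Cl)cc2n1C` gives > 10000 nM, a limit of the assay.
compound 3 `Cc1ccc2[nH]c(C)c(C(=O)Nc3ccc(Oc4ncnc5[nH]cc(-c6ccccc6)c45)c(F)c3)c(=O)c2c1` gives 560 nM.

In an assay on isolated protein for inhibition of tyrosine-protein kinase receptor UFO (Homo sapiens), read by FRET and Z'-LYTE, with a stated time of 1.5 h (on this read-out higher numbers stand for weaker inhibition and lower numbers for stronger inhibition), compound 1 gives only a limit, > 10000 nM, not a number. Compound 2 likewise sits at a limit, > 10000 nM. The step that the two limits leave unreadable from compound 1 to compound 2 cannot be read because the limit of > 10000 nM in this assay, at which 2 of the 3 values shown sit, holds both ends. Among the measured compounds shown here, compound 3 differs from compound 1 in more than one place, so its value stands alone and yields no single step. Compound 4 `CCc1ccc2c(c1)c(=O)c(C(=O)Nc1ccc(Oc3ncnc4[nH]cc(-c5ccccc5)c34)c(F)c1)c(C)n2C` differs from compound 1 by ethyl in place of hydrogen on an aromatic carbon. For the measured compounds named here, no measured step bears on this change; the only step of a single substituent on that ring is unreadable. Compound 4 is therefore expected to stay near the limit, with an estimated step that the limit leaves unreadable from compound 1 to compound 4 not beyond the scatter. Compound 4 is estimated at 15000 nM, between 3000 nM and 60000 nM.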

Compound 4, half-maximal inhibitory concentration: 6 nM
For compound 4 the middle estimate is 2500-fold (3.40 log units) above the measured one; the measured number lies below the stated range.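

On this aromatic carbon, meta to a fused ring and para to a fused ring, ethyl in place of hydrogen gives an at least 1600-fold lower number from compound 1 to compound 4 (3.22 log units; beyond the scatter) in this assay. A single substituent at this position is thus enough to bring the core of compound 1 away from the limit into a measurable range. The step is a bound and not a full size because compound 1 stands at a limit: the limit of > 10000 nM in this assay, at which 2 of the 4 values shown sit.

On these data alone, whether a propyl chain, an amine or a carboxylic acid on the same carbon would keep this level stays open. Also open, as far as these compounds go, is how much of the step belongs to ethyl itself rather than to any group at this carbon.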